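Swapping one aromatic group on a weak inhibitor

The compounds below may be only part of what the source reports. "The series", "measured", "known", "first", "only" and "open" are said of these compounds alone.

Measured so far:
- compound 1 `O=S(=O)(NCCNC(=S)Nc1cc(C(F)(F)F)cc(C(F)(F)F)c1)c1ccc(-c2ccccc2OCc2cccc(O)c2)s1` with 12000 nM
- compound 2 `COc1ccc(NC(=O)NCCNS(=O)(=O)c2ccc(-c3ccccc3OCc3ccccc3)s2)cc1` with > 20000 nM (a limit)

Going by the values given here, in a functional assay on RS4-11 cells (Homo sapiens) for inhibition, read by CCK-8 assay, with a stated time of 48 h (a higher number here means a weaker inhibitor, a lower number a stronger inhibitor), compound 1 gives 12000 nM, the only actual number so far. Compound 2 gives > 20000 nM, which is a limit of the assay and not a number.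

Compound 3 `O=[N+]([O-])c1ccc(Oc2ccccc2-c2ccc(S(=O)(=O)NCCNC(=S)Nc3cc(C(F)(F)F)cc(C(F)(F)F)c3)s2)cc1` keeps the core of compound 1 but has 4-nitrophenyl in place of 3-hydroxybenzyl on an oxygen on an aromatic ring. Among the compounds with values here, no measured pair tests this change, so no step beyond the usual scatter is expected. The expected size is a 1.2-fold lower number from compound 1 to compound 3 (0.08 log units; within the scatter). For compound 3 the estimate is 10000 nM, with an expected range from 3000 nM to 20000 nM.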

Compound 3, half-maximal inhibitory concentration: 6300 nM
Compound 3: middle estimate off by 1.6-fold (0.20 log units), on the high side; measured number inside the range.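

In this assay, replacing 3-hydroxybenzyl with 4-nitrophenyl on this oxygen gives a 1.9-fold lower number from compound 1 to compound 3 (0.28 log units; within the scatter). This first measured pair therefore shows that these two aromatic groups cannot be told apart at this position, although neither gives a strong inhibitor. No measurement shown bears on what lies behind this result.

Going by these compounds, whether any group on this oxygen can move the number beyond the usual scatter remains open. A plain methyl, a carboxylic acid on the aromatic ring, or an amine at the end of a longer chain would each test this.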